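Swapping a cyclopentyl for a pyrrole on the triazole core

The compounds below may be only part of what the source reports. "The series", "measured", "known", "first", "only" and "open" are said of these compounds alone.

Measured so far:
- compound 2 `COC(=O)c1nc(C2CCCC2)n(-c2ccc(F)cc2)n1`: 10400 nM
- compound 1 `COC(=O)c1nc(C2CC2)n(-c2ccc(F)cc2)n1`: 95900 nM

In a functional assay on NPC-TW01 cells (Homo sapiens) for inhibition, read by MTT assay, with a stated time of 72 h (on this read-out higher numbers stand for weaker inhibition of growth and lower numbers for stronger inhibition of growth), compound 2 gives the lower of the two numbers, and the step of a 9.2-fold lower number from compound 1 to compound 2 (0.96 log units; beyond the scatter) separates it from compound 1. Compound 3 `COC(=O)c1nc(-c2ccc[nH]2)n(-c2ccc(F)cc2)n1` differs from compound 2 by 1H-pyrrol-2-yl in place of cyclopentyl on an aromatic carbon. Among the compounds with values here, the only measured step compares two non-aromatic carbon rings, so it says little about replacing such a ring with one five-membered aromatic ring with 1 hetero atom. Within the data shown here, with no bearing step, compound 3 is expected to land near compound 2, a step of a 1.2-fold higher number from compound 2 to compound 3 (0.06 log units; within the scatter), estimated at 12000 nM within 3000 nM to 50000 nM.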

Compound 3, concentration for 50% growth inhibition: 9580 nM
Estimate against measurement, compound 3: 1.3-fold (0.10 log units) above, within the range that was stated.
By their numbers in this assay, from the lowest: compounds 3 and 2 (each within the scatter of the next); then compound 1.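

In this assay, the step shows a 1.1-fold lower number from compound 2 to compound 3 (0.04 log units; within the scatter), so at this position an aromatic 1H-pyrrol-2-yl and a non-aromatic cyclopentyl cannot be told apart, even though only 1H-pyrrol-2-yl carries a hydrogen-bond donor. The step also shows a 10-fold lower number from compound 1 to compound 3 (1.00 log units; beyond the scatter), so cyclopropyl falls behind this aromatic ring as well as behind cyclopentyl. No supporting evidence accounts for these results. Whether the hydrogen-bond donor matters remains open, since the compounds shown include no N-methylpyrrol-2-yl or furan-2-yl group. On these data alone, a phenyl ring or a six-membered cyclohexyl ring at this position also remains untested here.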